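The compounds below may be only part of what the source reports. "The series", "measured", "known", "first", "only" and "open" are said of these compounds alone.

Values measured in an ADME assay on MDCK cells (Canis lupus familiaris) for permeability, in the apical to basolateral direction (on this read-out lower numbers stand for lower permeability and higher numbers for higher permeability), are as follows

Compound 1 `CC(C)C(/C=C1\NC(=O)NC1=O)c1ccc(-c2ccc3cccc(F)c3c2)[nH]c1=O` gives 12.3 10^-6 cm/s
Compound 2 `CC(C)C(CC1C(=O)NC(=O)N1C)c1ccc(-c2ccc3cccc(F)c3c2)[nH]c1=O` gives 17.6 10^-6 cm/s
Compound 3 `CC(C)[C@@H](c1ccc(-c2ccc3cccc(F)c3c2)[nH]c1=O)[C@@H]1OC(=O)NC1=O` gives 3.15 10^-6 cm/s

Compound 3 has the lowest of these numbers, and both of the others lie beyond the scatter from it. Compound 4 `CC(C)[C@H](C[C@H]1OC(=O)NC1=O)c1ccc(-c2ccc3cccc(F)c3c2)[nH]c1=O` is not yet measured. In it, (2,4-dioxo-1,3-oxazolidin-5-yl)methyl stands in place of 2,4-dioxo-1,3-oxazolidin-5-yl on a saturated chain carbon bound to an aromatic carbon and a saturated chain carbon: (2,4-dioxo-1,3-oxazolidin-5-yl)methyl in place of 2,4-dioxo-1,3-oxazolidin-5-yl on a saturated chain carbon bound to an aromatic carbon and a saturated chain carbon.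

Among the measured compounds shown here, no measured step makes this same change, so the evidence is indirect. For the measured compounds named here, the one step available, a 1.4-fold higher number from compound 1 to compound 2 (0.16 log units; within the scatter), exchanges one ring group for a slightly larger one and stays within the scatter. It gives no reason to expect a large jump in this assay. Compound 2, whose ring group also sits on a saturated link, reaches 17.6 10^-6 cm/s, which hints at a rise rather than a fall. The expected change is modest, a 2.2-fold higher number from compound 3 to compound 4 (0.35 log units; beyond the scatter). For compound 4 the estimated value is 7 10^-6 cm/s, with an expected range from 2.5 10^-6 cm/s to 16 10^-6 cm/s.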

Compound 4, apparent permeability: 10.3 10^-6 cm/s
Compound 4: the middle estimate sits 1.5-fold (0.17 log units) below what was measured, within the range that was stated.
By their numbers in this assay, from the lowest: compound 3; then compounds 4, 1 and 2 (each within the scatter of the next).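

On this saturated chain carbon, the ring itself stays the same and only the link to it changes: (2,4-dioxo-1,3-oxazolidin-5-yl)methyl replaces 2,4-dioxo-1,3-oxazolidin-5-yl, and this assay gives a 3.3-fold higher number from compound 3 to compound 4 (0.51 log units; beyond the scatter). The earlier step changed the ring group and stayed within the scatter, so it could not show that this position responds to a change in the link. The low number of compound 3 therefore does not follow from the presence of this ring alone, since the same ring, with the same counted hydrogen-bond donors and acceptors, gives a clearly higher number in compound 4.

Nothing available explains this rise. Going by these compounds, whether a longer chain carrying the same ring would raise the number further, or a carboxylic acid in place of the ring would keep it, remains open.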